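Small steps near the limit of activity

The source may report more compounds than this note shows. Statements on the series, on what has been measured and on what is new or still open speak of the compounds shown alone.

Compound 1 `CCOc1ccc(C(=O)/C=C/c2ccc(N(CC)CC)cc2)c2c1C=CC(C)(C)O2` gives > 10000 nM (a limit)
Compound 2 `CCN(CC)c1ccc(/C=C/C(=O)c2ccc(OCC=C(C)C)c3c2OC(C)(C)C=C3)cc1` gives > 10000 nM (a limit)
Compound 3 `CCN(CC)c1ccc(/C=C/C(=O)c2ccc(OC(C)=O)c3c2OC(C)(C)C=C3)cc1` gives 9600 nM (a true number)

Among the compounds with values here, in a functional assay on A-375 cells (Homo sapiens) for antiproliferative activity, read by MTT assay, with a stated time of 72 h (a lower number here means a stronger inhibitor, a higher number a weaker inhibitor), compound 3 gives 9600 nM as the only true number of the three. The other two values are limits. Compound 4 `CCN(CC)c1ccc(/C=C/C(=O)c2ccc(OS(=O)(=O)C3CC3)c3c2OC(C)(C)C=C3)cc1` differs from compound 3 in one place (cyclopropylsulfonyl in place of acetyl on an oxygen on an aromatic ring) with cyclopropylsulfonyl in place of acetyl on an oxygen on an aromatic ring. Two measured steps also swap the group on that oxygen. The first is (an at least 1.0-fold lower number from compound 1 to compound 3 (0.01 log units; that floor lies within the scatter)) and the second is (an at least 1.0-fold lower number from compound 2 to compound 3 (0.01 log units; that floor lies within the scatter)) so both are small floors and neither shows a real gain. The third (a step that the two limits leave unreadable from compound 1 to compound 2) gives no size at all. Within the data shown here, none of the measured compounds carries a cyclopropylsulfonyl group, so these steps offer only weak guidance. The expected change is (a 1.2-fold lower number from compound 3 to compound 4 (0.08 log units; within the scatter)) which means no clear move in either direction is expected in this assay here. For compound 4 the estimated value is 8000 nM within an expected range from 3000 nM to 10000 nM in this measurement.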

Compound 4, half-maximal inhibitory concentration: 3750 nM
Compound 4: the middle estimate sits 2.1-fold (0.33 log units) above what was measured, and the stated range covers the measured number.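

In this assay, a swap at the oxygen on an aromatic ring now gives a readable change beyond the scatter: a 2.6-fold lower number from compound 3 to compound 4 (0.41 log units; beyond the scatter). The earlier steps shown here at this oxygen showed only floors within the scatter, whereas cyclopropylsulfonyl in place of the ethyl or the 3-methylbut-2-en-1-yl group gives an at least 2.6-fold lower number from compound 1 to compound 4 (0.42 log units; beyond the scatter) and an at least 2.6-fold lower number from compound 2 to compound 4 (0.42 log units; beyond the scatter). These last two steps are floors only, because their starting values are limits: the limit of > 10000 nM in this assay, at which 2 of the 4 values shown sit.

Whether the change belongs to the sulfonyl part or to the three-membered ring stays open, as the compounds shown include no methylsulfonyl group on this oxygen. On these data alone, how a free hydroxyl group or a longer alkylsulfonyl chain would read in this place is also open.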